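The source may hold more compounds than are shown below. What is called first, only, known or untested is meant among the compounds shown, and "the series" means these compounds.

Working notes on the diacylhydrazine series.

Three compounds share one core and differ only in the aryl group on one carbonyl carbon. In an assay on cells for agonist activity at ecdysone receptor (Bombyx mori), read by a luciferase reporter, with a stated time of 24 h (on this read-out lower numbers stand for an effect already at smaller amounts and higher numbers for an effect only at larger amounts of compound), compound 1 `CC(C)(C)N(NC(=O)c1ccccc1F)C(=O)c1ccccc1Cl` gives 51.3 nM. Compound 2 `CCc1ccc(C(=O)NN(C(=O)c2ccccc2Cl)C(C)(C)C)cc1` gives 5.75 nM in this assay, and compound 3 `Cc1cccc(C(=O)NN(C(=O)c2ccccc2Cl)C(C)(C)C)c1C` gives 20 nM. The steps are all of the same kind: an 8.9-fold lower number from compound 1 to compound 2 (0.95 log units; beyond the scatter), a 2.6-fold lower number from compound 1 to compound 3 (0.41 log units; beyond the scatter) and a 3.5-fold higher number from compound 2 to compound 3 (0.54 log units; beyond the scatter). On these numbers compound 2 stands lowest of the three, with compound 3 nearest and compound 1 furthest.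

Compound 4 `CCc1ccc(C(=O)NN(C(=O)CCC(C)C)C(C)(C)C)cc1` is not yet measured in this assay. Relative to compound 2 the change is isopentyl in place of 2-chlorophenyl on a carbonyl carbon. Within the data shown here, no measured step touches this part of the core: every step so far exchanges one aryl group for another on the other carbonyl carbon, and even those gave only modest movements. Loss of the only ring on this side, with an open chain entering, has no direct precedent here, so the expectation rests on little and must carry a wide range. The working assumption is that compound 4 is expected to show a clearly higher number than compound 2, a step estimated at a 35-fold higher number from compound 2 to compound 4 (1.54 log units; beyond the scatter). Compound 4 is therefore estimated at 200 nM, within a range of 20 nM to 2000 nM.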

Compound 4, half-maximal effective concentration: 832 nM
Compound 4: the middle estimate sits 4.2-fold (0.62 log units) below what was measured; the measured number falls inside the stated range.
By their numbers in this assay, from the lowest: compound 2; then compound 3; then compound 1; then compound 4.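

In this assay the exchange of isopentyl for 2-chlorophenyl gives a 140-fold higher number from compound 2 to compound 4 (2.16 log units; beyond the scatter) and so exceeds every aryl exchange on the other carbonyl carbon, where an 8.9-fold lower number from compound 1 to compound 2 (0.95 log units; beyond the scatter) was the largest. Among these compounds, this is the first sign that the carbonyl carbon carrying the 2-chlorophenyl group tolerates a change less well than the other carbonyl carbon tolerated its aryl exchanges, although it rests on a single pair of compounds, and a change of one kind at each position is not a like-for-like test. The change also removes the ring and the chlorine together, so the step belongs to the whole group and to neither part alone, and nothing available bears on its cause.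

The compounds shown leave open whether the ring or the chlorine accounts for the step, which plain phenyl or cyclohexyl at this carbonyl carbon would begin to separate, and whether a longer chain or a shorter one such as propyl would move the number further. They also leave open whether isopentyl costs as much when the 4-ethylphenyl on the other carbonyl carbon is replaced by 2-fluorophenyl or 2,3-dimethylphenyl.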